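Swapping the Thiophene on Two Related Cores

A few compounds are considered here, and "the series" means these few. Any claim that something is new, unique, unknown or untested is made for them only; others in the source may bear on it.

Compound 1 `Cc1cc(-c2nc3sc(C)cn3c2/C=N/NC(=N)N)c(C)s1` and compound 2 `Cc1cn2c(/C=N/NC(=N)N)c(-c3cccs3)nc2s1` share one core, while compound 3 `Cc1cc(-c2nc3n(c2/C=N/NC(=N)N)CCS3)c(C)s1` and compound 4 `N=C(N)N/N=C/c1c(-c2cccs2)nc2n1CCS2` share another; the difference between the two cores is not broken down here. In a functional assay on cells (Leukemia cell, Homo sapiens) for inhibition (a higher number here means a weaker inhibitor of growth, a lower number a stronger inhibitor of growth), compound 1 gives 47900 nM, compound 2 gives 1820 nM, and compound 3 gives 20900 nM. The change thiophen-2-yl in place of 2,5-dimethylthiophen-3-yl on an aromatic carbon brought a 26-fold lower number from compound 1 to compound 2 (1.42 log units; beyond the scatter). The same kind of change, (thiophen-2-yl in place of 2,5-dimethylthiophen-3-yl on an aromatic carbon), leads from compound 3 to compound 4; around its place, the site in compound 3 additionally lies two ring bonds from two ring atoms that each bear a fused ring. Because the earlier pair showed a 26-fold lower number from compound 1 to compound 2 (1.42 log units; beyond the scatter), compound 4 is expected to show a 14-fold lower number from compound 3 to compound 4 (1.14 log units; beyond the scatter) in this assay, kept somewhat smaller since a single pair supports it. For compound 4 the estimated value is 1500 nM, between 400 nM and 5000 nM.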

Compound 4, concentration for 50% growth inhibition: 18600 nM
Compound 4: middle estimate off by 12-fold (1.09 log units), on the low side; measured number outside the range, above it.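

On the core of compound 3, thiophen-2-yl in place of 2,5-dimethylthiophen-3-yl gave a 1.1-fold lower number from compound 3 to compound 4 (0.05 log units; within the scatter) in this assay, so the large step seen on the core of compound 1 did not carry over. The two steps do not agree: the same change on two cores in this assay, a 26-fold lower number (1.42 log units; beyond the scatter) from compound 1 to compound 2 and a 1.1-fold lower number (0.05 log units; within the scatter) from compound 3 to compound 4, 23-fold (1.37 log units) apart, beyond the scatter of two such steps. This shows that the size of this change differed between these two cores, but two pairs do not show which difference between the cores goes with it, or how a third core would behave.

The compounds shown leave open whether the methyl groups or the point of attachment of the thiophene matters more. They also leave open whether a phenyl group or an amine at this place would differ between the two cores.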